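Replacing Amino with Fluoro on an Aromatic Carbon

A few compounds are considered here, and "the series" means these few. Any claim that something is new, unique, unknown or untested is made for them only; others in the source may bear on it.

Measured in an ADME assay on L6 cells (Rattus norvegicus) for cytotoxicity; on this read-out lower numbers stand for stronger inhibition and higher numbers for weaker inhibition:
- Compound 1 `CC1CCc2ccccc2N1S(=O)(=O)c1ccc([N+](=O)[O-])cc1`: 248000 nM
- Compound 2 `CC1CCc2ccccc2N1S(=O)(=O)c1ccc(N)cc1`: 35300 nM

Compound 2 holds the lower of the two numbers. Compound 3 `CC1CCc2ccccc2N1S(=O)(=O)c1ccc(F)cc1` has not yet been measured and carries fluoro in place of amino on an aromatic carbon, para to a large group: fluoro in place of amino on an aromatic carbon. Among the compounds with values here, the only measured step that bears on this change is a 7.0-fold lower number from compound 1 to compound 2 (0.85 log units; beyond the scatter), a modest one in which amino replaced nitro. Compound 3 also gives up the amino group, so a modest rise of similar or smaller size is expected in this assay, toward weaker inhibition. The expected step is a 2.5-fold higher number from compound 2 to compound 3 (0.41 log units; beyond the scatter). The estimate for compound 3 is 90000 nM, within an expected range of 30000 nM to 250000 nM.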

Compound 3, half-maximal inhibitory concentration: 67600 nM
For compound 3 the middle estimate is 1.3-fold (0.12 log units) above the measured one; the range from low to high includes it.
By their numbers in this assay, from the lowest: compounds 2 and 3 (each within the scatter of the next); then compound 1.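

In this assay, fluoro in place of amino gives a 1.9-fold higher number from compound 2 to compound 3 (0.28 log units; within the scatter) and so leaves the two compounds indistinguishable, although fluoro has no hydrogen-bond donor or acceptor and amino has one of each. Fluoro in place of nitro gives a 3.7-fold lower number from compound 1 to compound 3 (0.56 log units; beyond the scatter) and sets compound 1 apart from both others. No supporting measurement explains these numbers.

Open, on these data alone, is whether a carboxylic acid or a methoxy group on this aromatic carbon would fall with compound 2 and compound 3 or with compound 1. Also open, as far as these compounds go, is whether these steps would hold on a different core.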